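Compound 4: a chlorophenyl swap at the assay limit

This account rests on a few compounds, and the source may have more. Where it says the series, first, only, none or still open, it means among the compounds named here.

- compound 1 `C=C[C@@](C)(/C=C/c1ccc(O)cc1)CC/C=C/C#N`: > 43400 nM
- compound 2 `C=C[C@@](C)(/C=C/c1ccc(O)c(/C=C/c2ccc(Cl)cc2)c1)CCC=C(C)C`: > 43400 nM
- compound 3 `CCOc1ccc(/C=C/[C@@](C)(/C=C/c2ccc(O)cc2)CCC=C(C)C)cc1`: > 43400 nM

The test here is a functional assay on NALM-6 cells (Homo sapiens) for cytotoxicity, with a stated time of 72 h (a lower number here means that less compound is needed, a higher number that more compound is needed for the effect), and its read-out is the half-maximal effective concentration. In this assay compound 3 gives > 43400 nM, which is a limit and not a number. It stands with the other two compounds, at the limit of > 43400 nM in this assay, at which 3 of the 3 values shown sit.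

Compound 4 `CC(C)=CCC[C@](C)(/C=C/c1ccc(O)cc1)/C=C/c1cccc(Cl)c1` has not yet been measured. It differs from compound 3 in one place: 3-chlorophenyl in place of 4-ethoxyphenyl on a double-bonded chain carbon bound to a double-bonded chain carbon. This puts 3-chlorophenyl in place of 4-ethoxyphenyl on a double-bonded chain carbon bound to a double-bonded chain carbon.

Among the measured compounds shown here, no step between measured compounds is available as a guide, and no compound so far has given an actual number. The expectation therefore rests on compound 3, whose > 43400 nM is a limit. No change beyond the usual scatter is expected in this assay, and another limit is the likeliest result. The expected step is a step that the limit leaves unreadable from compound 3 to compound 4. For compound 4 the estimate is 45000 nM, with an expected range of 20000 nM to 90000 nM.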

Compound 4, half-maximal effective concentration: > 43400 nM
Compound 4: only a limit was reported (the forecaster's own chance of this, stated with the estimate: 70%); the middle value is on the limit's open side.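

In this assay, compound 3 and compound 4 each give only a limit and not a number, so the step between them cannot be read: the limit of > 43400 nM in this assay, at which 4 of the 4 values shown sit.

The compounds shown leave open whether 3-chlorophenyl in place of 4-ethoxyphenyl makes any difference in this assay, and what concentration any of them would need for the effect.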